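Butyl to benzyl on the amine: expected step

This account rests on a few compounds, and the source may have more. Where it says the series, first, only, none or still open, it means among the compounds named here.

Within the data shown here, in a functional assay on HeLa cells (Homo sapiens) for antiproliferative activity, read by cell counting, with a stated time of 2 days (on this read-out lower numbers stand for stronger inhibition and higher numbers for weaker inhibition), compound 2 (`CCCCN(C)c1nc(N)c(C(=O)c2cc(OC)c(OC)c(OC)c2)s1`) gives 31000 nM as the higher of the two numbers so far, and compound 1 (`COc1cc(C(=O)c2sc(N(C)C)nc2N)cc(OC)c1OC`) gives 8200 nM as the lower.

Compound 3 (`COc1cc(C(=O)c2sc(N(C)Cc3ccccc3)nc2N)cc(OC)c1OC`) carries phenyl in place of propyl on a saturated chain carbon bound to a nitrogen on an aromatic ring. Among the measured compounds shown here, one measured step bears on this place, with propyl in place of hydrogen: a 3.8-fold higher number from compound 1 to compound 2 (0.58 log units; beyond the scatter) is modest. For the measured compounds named here, no measurement yet shows phenyl at this place. Going by the values given here, with that single modest step as the only guide, no large change is expected, and the slight lean is toward a lower number. The expected step is a 1.6-fold lower number from compound 2 to compound 3 (0.19 log units; within the scatter) and no step beyond the scatter is anticipated. Compound 3 is estimated at 20000 nM with an expected range of 7000 nM to 60000 nM in this series.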

Compound 3, half-maximal inhibitory concentration: > 200000 nM
Compound 3: a limit, no number (the forecaster's own chance of this, stated with the estimate: 15%); middle value at least 10-fold (1.00 log units) from the limit.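

Compound 3 in this assay stands as a limit of the assay and not as a number: the limit of > 200000 nM in this assay, at which 1 of the 3 values shown sits.
Phenyl in place of propyl on a saturated chain carbon bound to a nitrogen on an aromatic ring gives an at least 6.4-fold higher number from compound 2 to compound 3 (0.80 log units; beyond the scatter) and phenyl in place of hydrogen there gives an at least 24-fold higher number from compound 1 to compound 3 (1.38 log units; beyond the scatter) in the same assay. Among these compounds, the only earlier step at this position was modest, a 3.8-fold higher number from compound 1 to compound 2 (0.58 log units; beyond the scatter) and so the butyl to benzyl change shows that what sits on this amine, not only whether the chain is extended, can move this assay well beyond the scatter.

The limit leaves the true size of both new steps open. As far as these compounds go, whether the phenyl ring or the larger group as such drives the loss also stays open, and a longer chain such as hexyl or a cyclohexylmethyl group on the same amine would separate the two.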